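Cytotoxicity notes on the series, step compound 3 to compound 4

A few compounds are considered here, and "the series" means these few. Any claim that something is new, unique, unknown or untested is made for them only; others in the source may bear on it.

compound 1 `CCOC(=O)c1ccc(NC(=O)CSc2snnc2-c2ccc(Cl)cc2Cl)c(Br)c1`: > 228000 nM (a limit of the assay)
compound 2 `Cc1ccc(NC(=O)CSc2snnc2-c2ccc(F)cc2F)c(Br)c1`: > 273000 nM (a limit of the assay)
compound 3 `COc1ccc(-c2nnsc2SCC(=O)Nc2ccc(C)cc2Br)cc1`: 249000 nM

In an ADME assay on MT4 cells (Homo sapiens) for cytotoxicity (on this read-out lower numbers stand for higher toxicity in this test and higher numbers for lower toxicity in this test), compound 1 gives > 228000 nM, which is a limit of the assay and not a number. Compound 2 gives > 273000 nM, likewise a limit. Compound 3 gives 249000 nM and is the only one of the three with a measured number. It stands in the same region as the values of compound 1 and compound 2. Among the measured compounds shown here, the single step between measured compounds that differ in one place runs an at least 1.0-fold lower number from compound 2 to compound 3 (0.03 log units; that floor lies within the scatter), 4-methoxyphenyl in place of 2,4-difluorophenyl on an aromatic carbon; it starts from a limit of > 273000 nM in this assay, at which 1 of the 3 values shown sits, and tells nothing beyond the scatter.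

Compound 4 `CCOC(=O)c1ccc(NC(=O)CSc2snnc2-c2ccc(OC)cc2)c(Br)c1` differs from compound 3 by ethoxycarbonyl in place of methyl on an aromatic carbon. For the measured compounds named here, no measured step covers this change. Compound 1 also carries the ethoxycarbonyl group, but in this assay it shows only a limit (the limit of > 228000 nM in this assay, at which 1 of the 3 values shown sits), so no direction can be read from it. The step from compound 3 to compound 4 is therefore expected as a 1.1-fold lower number from compound 3 to compound 4 (0.03 log units; within the scatter), none beyond the scatter. Compound 4 is expected to give 230000 nM in this assay, with a range from 120000 nM to 400000 nM, and it may well be reported only as a limit.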

Compound 4, half-maximal cytotoxic concentration: > 245000 nM
Compound 4: no number, only a limit (the forecaster's own chance of this, stated with the estimate: 60%); at least 1.0-fold (0.02 log units) between middle value and limit.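

In this assay compound 4 gives > 245000 nM, a limit of the assay and not a number. The steps from compound 3 to compound 4 and from compound 1 to compound 4 cannot be read. The compounds shown leave open whether ethoxycarbonyl in place of methyl on an aromatic carbon changes this read-out at all.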